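Para-substituent swap on a thiosemicarbazone series

The source may report more compounds than this note shows. Statements on the series, on what has been measured and on what is new or still open speak of the compounds shown alone.

Compound 1, `CC1=CC[C@H](C(C)(C)N=C=S)CC1`: in a functional assay on MCF7 cells (Homo sapiens) for inhibition, read by sulforhodamine B assay, with a stated time of 48 h (a lower number here means a stronger inhibitor of growth, a higher number a weaker inhibitor of growth), compound 1 gives > 100000 nM, which is a limit of the assay and not a number.
Compound 2, `CC1=CC[C@H](C(C)(C)NC(=S)N/N=C/c2ccc(O)cc2)CC1`: in this assay compound 2 gives > 100000 nM, again a limit of the assay.
Compound 3, `CC1=CC[C@H](C(C)(C)NC(=S)N/N=C/c2ccc(N(C)C)cc2)CC1`: in this assay compound 3 gives > 100000 nM, also a limit of the assay.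

Compound 3 therefore stands only at a limit in this assay, and the same holds for the two other measured compounds, as summarised by the limit of > 100000 nM in this assay, at which 3 of the 3 values shown sit. For the measured compounds named here, the one measured step that touches compound 3, a step that the two limits leave unreadable from compound 2 to compound 3, is of a size that the two limits leave unreadable.

Compound 4, `CC1=CC[C@H](C(C)(C)NC(=S)N/N=C/c2ccc(Cl)cc2)CC1`, is not yet measured. It differs from compound 3 by chloro in place of dimethylamino on an aromatic carbon. Going by the values given here, no measured step gives a readable size for any change at this position, so the step to compound 4 cannot be sized from the data and no direction can be read. In this assay compound 4 is expected to give 150000 nM, within a range from 30000 nM to 600000 nM, which most likely means that the assay again reports only its limit. This estimate corresponds to an expected step that the limit leaves unreadable from compound 3 to compound 4.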

Compound 4, concentration for total growth inhibition: > 100000 nM
Compound 4 gave a limit, no number; the forecaster's own chance of this, stated with the estimate: 75%; the middle value does not contradict the limit.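

The steps among compound 2, compound 3 and compound 4 cannot be read, because each of these compounds stands at a limit of this assay and not at a number: the limit of > 100000 nM in this assay, at which 4 of the 4 values shown sit.

The compounds shown leave open whether any other group at this aromatic carbon, or any change to the shared core, would give a measurable value in this assay.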